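Methyl in place of fluoro on the benzyl ring

The source may report more compounds than this note shows. Statements on the series, on what has been measured and on what is new or still open speak of the compounds shown alone.

Compound 1, `NC(=O)N1CCN(C(=S)SCc2cn(Cc3ccc(F)cc3)nn2)CC1`, gives 62700 nM in a functional assay on EC9706 cells (Homo sapiens) for cytotoxicity, read by MTT assay, with a stated time of 72 h; a lower number here means a stronger inhibitor, a higher number a weaker inhibitor.
Compound 2, `CCN(C)C(=O)N1CCN(C(=S)SCc2cn(Cc3ccc(F)cc3)nn2)CC1`, gives 14300 nM in this assay.
Compound 3, `O=C(NC1CCCCC1)N1CCN(C(=S)SCc2cn(Cc3ccc(F)cc3)nn2)CC1`, reaches only the assay limit of > 128000 nM in this assay.

Among the two numbers, compound 2 stands lowest; the step of a 4.4-fold lower number from compound 1 to compound 2 (0.64 log units; beyond the scatter) lies beyond the scatter, as does an at least 8.9-fold higher number from compound 2 to compound 3 (0.95 log units; beyond the scatter), which ends at the limit of > 128000 nM in this assay, at which 1 of the 3 values shown sits.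

Compound 4, `CCN(C)C(=O)N1CCN(C(=S)SCc2cn(Cc3ccc(C)cc3)nn2)CC1`, differs from compound 2 by methyl in place of fluoro on an aromatic carbon. Within the data shown here, every measured step above changes the urea end of the shared core; none touches the benzyl ring, so no step here bears on this swap. With no guide, the expected change for compound 4 is none beyond the scatter: no change at the digits printed from compound 2 to compound 4 (within the scatter). Compound 4 is therefore estimated at 14300 nM in this assay, within 5000 nM to 40000 nM.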

Compound 4, half-maximal inhibitory concentration: 70600 nM
The estimate for compound 4 lay 4.9-fold (0.69 log units) below the measured number, and the stated range ends below it.
By their numbers in this assay, from the lowest: compound 2; then compounds 1 and 4 (each within the scatter of the next). At a limit, above all of these: compound 3.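

The benzyl ring matters as well as the urea end: in this assay, 4-methylbenzyl in place of 4-fluorobenzyl gives a 4.9-fold higher number from compound 2 to compound 4 (0.69 log units; beyond the scatter). Among these compounds, all earlier steps changed only the urea end, so this is the first sign that exchanging a single heavy atom on the aromatic ring, para to a large group, can shift the number beyond the scatter. Nothing measured here accounts for the size or direction of this step.

On these data alone, whether chloro, methoxy or plain hydrogen at this position would fall nearer compound 2 or compound 4 stays open. So does whether the swap would act the same with the cyclohexylamino urea end.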